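Swapping the pyrrole for a chlorophenyl on the enone chain

A few compounds are considered here, and "the series" means these few. Any claim that something is new, unique, unknown or untested is made for them only; others in the source may bear on it.

Measured compounds in a functional assay on DU-145 cells (Homo sapiens) for inhibition, read by trypan blue exclusion, with a stated time of 96 h; on this read-out lower numbers stand for stronger inhibition of growth and higher numbers for weaker inhibition of growth:
compound 1 `Cc1ccc(S/C(=C/c2c(O)cc(O)cc2O)C(=O)c2ccc(Cl)cc2)cc1` — > 100000 nM
compound 2 `Cc1ccc(S/C(=C/c2ccc[nH]2)C(=O)c2ccc(Cl)cc2)cc1` — 10000 nM
compound 3 `O=C(/C(=C\c1ccc[nH]1)SCc1ccc(Cl)cc1)c1ccc(Cl)cc1` — 10000 nM

The value of compound 1 in this assay is a limit of the assay the limit of > 100000 nM in this assay, at which 1 of the 3 values shown sits, and not a number. Compound 2 stands level with compound 3, the step of no change at the digits printed from compound 2 to compound 3 (within the scatter) showing that exchanging the group on the sulfur left the read-out unchanged. The step of an at least 10-fold lower number from compound 1 to compound 2 (1.00 log units; beyond the scatter) is the only one here that touches the aryl group on the double-bonded chain carbon, and it was sizeable.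

Compound 4 `Cc1ccc(S/C(=C/c2ccc(Cl)cc2)C(=O)c2ccc(Cl)cc2)cc1` is not yet measured in this assay. It differs from compound 2 in this way: 4-chlorophenyl in place of 1H-pyrrol-2-yl on a double-bonded chain carbon bound to a double-bonded chain carbon. The step from compound 1 to compound 2 concerns a different aryl group and gives no direct guide to a 4-chlorophenyl here, and the step from compound 2 to compound 3 concerns the sulfur and not this position. Among the measured compounds shown here, no measured step therefore bears directly on this change, and the expectation is a step of no clear direction beyond the scatter.

Compound 4 is estimated to give 10000 nM in this assay, with a likely range of 3000 nM to 40000 nM. This estimate amounts to no change at the digits printed from compound 2 to compound 4 (within the scatter).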

Compound 4, concentration for 50% growth inhibition: 10000 nM
Compound 4: the middle estimate sits on the measured number at the digits printed, and the stated range covers the measured number.
By their numbers in this assay, from the lowest: compounds 2, 3 and 4 (each within the scatter of the next). At a limit, above all of these: compound 1.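

At the double-bonded chain carbon, the ring could be exchanged without any effect on the read-out (no change at the digits printed from compound 2 to compound 4 (within the scatter)), so 4-chlorophenyl, a six-membered aromatic ring of carbon only, serves here as well as 1H-pyrrol-2-yl with its ring nitrogen. The 2,4,6-trihydroxyphenyl group also compares poorly with this second ring (an at least 10-fold lower number from compound 1 to compound 4 (1.00 log units; beyond the scatter)), so the lower number is not peculiar to the pyrrole. The value of compound 1 that both comparisons start from is a limit and not a number: the limit of > 100000 nM in this assay, at which 1 of the 4 values shown sits.

From the compounds shown here alone, what an amine or a carboxylic acid on the phenyl ring, or a simple methyl group in place of the ring, would do at this carbon stays open. So does whether any group here can bring the number below the level shared by compounds 2, 3 and 4.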